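The compounds below may be only part of what the source reports. "The series", "measured", "known", "first", "only" and "open" are said of these compounds alone.

Measured so far:
- compound 1 `COc1ccc(S(=O)(=O)c2cnc3ccc(F)cc3c2N2CCC(C)CC2)cc1` — 85%
- compound 2 `COc1ccc2ncc(S(=O)(=O)c3ccc(OC)c(Cl)c3)c(N3CCC(C)CC3)c2c1` — 21%
- compound 3 `CC1CCN(c2c(S(=O)(=O)c3ccccc3)cnc3cc(Cl)ccc23)CC1` — 93%

Three compounds have been run in an assay on isolated protein for displacement of a labelled ligand from metabotropic glutamate receptor 5 (Homo sapiens), with a stated time of 60 min, tested at 1 uM; on this read-out higher numbers stand for more inhibition at the one concentration tested (going by the name of the read-out) and lower numbers for less inhibition. Compound 1 gives 85%, the second highest of the three numbers. Its nearest neighbour is compound 3 with 93%, a number within the scatter of compound 1, so no order between these two can be read. Compound 2 gives 21%, far below compound 1 and clearly beyond the scatter. Among the measured compounds shown here, no step between two measured compounds that differ in a single place is available, so nothing directly sizes a one-place change.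

Compound 4 `CC1CCN(c2c(S(=O)(=O)c3ccccc3)cnc3ccc(F)cc23)CC1` has not been measured. It differs from compound 1 in one place: hydrogen in place of methoxy on an aromatic carbon. The same unsubstituted phenyl on the sulfone is found in compound 4 and in compound 3, and compound 3 gives 93%. On that basis a step of no size beyond the scatter is expected, no change at the digits printed from compound 1 to compound 4 (within the scatter). For compound 4 the estimated value is 85%, with an expected range from 65% to 97%.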

Compound 4, a percentage reported as inhibition, at one concentration (the size of the read-out at that concentration, not a potency): 40%
Estimate against measurement, compound 4: 45 percentage points above; the whole stated range lies above it.
By their numbers in this assay, from the lowest: compound 2; then compound 4; then compounds 1 and 3 (each within the scatter of the next).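

In this assay, among the compounds shown here, hydrogen in place of methoxy on an aromatic carbon, para to a large group, gives a number 45 percentage points lower from compound 1 to compound 4 (beyond the scatter), the first step that sizes a change in one place. With the rest of the structure held the same, this position is therefore not indifferent to its substituent: 4-methoxyphenyl and phenyl are clearly separated at the one concentration tested. No measurement available here offers an explanation for the step.

On these data alone, whether the oxygen or the methyl of the methoxy carries the difference remains open, and a hydroxyl or an ethoxy group at this place would help separate the two. Also open, as far as these compounds go, is whether the same change gives a step of similar size on a core other than that of compound 1.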